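Methoxy to dimethylcarbamoyl on the shared core

A few compounds are considered here, and "the series" means these few. Any claim that something is new, unique, unknown or untested is made for them only; others in the source may bear on it.

Measured so far:
compound 1 `COc1ccccc1C(=O)/C=C/c1ccccc1` at 2230 nM
compound 2 `O=C(/C=C/c1ccccc1)c1c(Cl)cccc1Cl` at 1080 nM

In a functional assay for inhibition, with Homo sapiens as the target (on this read-out higher numbers stand for weaker inhibition and lower numbers for stronger inhibition), compound 1 stands highest of the two measured compounds at 2230 nM and the gap down to compound 2 lies beyond the scatter. Compound 3 `CN(C)C(=O)c1ccccc1C(=O)/C=C/c1ccccc1` carries dimethylcarbamoyl in place of methoxy on an aromatic carbon of the core of compound 1. For the measured compounds named here, no measured pair shows this replacement. In this assay no step beyond the scatter is expected, and no direction can be argued from the data. The estimated step of a 1.2-fold lower number from compound 1 to compound 3 (0.07 log units; within the scatter) stays small. Compound 3 is expected at 1900 nM with a range from 650 nM to 5500 nM for now.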

Compound 3, half-maximal inhibitory concentration: 5500 nM
Compound 3: middle estimate off by 2.9-fold (0.46 log units), on the low side, and the stated range covers the measured number.
By their numbers in this assay, from the lowest: compound 2; then compound 1; then compound 3.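

In this assay, dimethylcarbamoyl in place of methoxy on an aromatic carbon, ortho to a large group, gives a 2.5-fold higher number from compound 1 to compound 3 (0.39 log units; beyond the scatter), a modest step. For the compounds shown here, this is the first sign that the number responds to the group at this position, here with more heavy atoms entering and the hydrogen-bond acceptor count unchanged. Nothing available explains the step. The compounds shown do not separate the number of heavy atoms from the kind of group. From the compounds shown here alone, how an amine, a carboxylic acid or a longer alkoxy chain would read on this aromatic carbon remains open.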